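Pyridinyl for Methoxyphenyl on a Triazole-Bearing Core

The source may hold more compounds than are shown below. What is called first, only, known or untested is meant among the compounds shown, and "the series" means these compounds.

Compound 1 `C=C1C[C@]23C[C@@]1(O)CC[C@H]2c1ccc(OS(=O)(=O)c2ccc(C)cc2)c(C)c1[C@@H]3Cn1cc(-c2ccc(OC)cc2)nn1` gives in a functional assay on A549 cells (Homo sapiens) for cytotoxicity, read by MTT assay, with a stated time of 4 days (a lower number here means a stronger inhibitor, a higher number a weaker inhibitor), only a limit, > 20000 nM.
Compound 2 `C=C1C[C@]23C[C@@]1(O)CC[C@H]2c1ccc(O)c(C)c1[C@@H]3Cn1cc(-c2ccc(OC)cc2)nn1` gives in this assay only a limit, > 20000 nM.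
Compound 3 `C=C1C[C@]23C[C@@]1(O)CC[C@H]2c1cc(Br)c(O)c(C)c1[C@@H]3Cn1cc(-c2ccc(C)cc2)nn1` gives in this assay only a limit, > 20000 nM.

Compound 1 therefore stands nowhere in particular: all three values sit at the same limit (the limit of > 20000 nM in this assay, at which 3 of the 3 values shown sit). Among the compounds with values here, the one single-point step, a step that the two limits leave unreadable from compound 1 to compound 2, cannot be read from two limits. Compound 2 and compound 3 differ in more than one place, so their values show nothing about one change. Compound 4 `C=C1C[C@]23C[C@@]1(O)CC[C@H]2c1ccc(OS(=O)(=O)c2ccc(C)cc2)c(C)c1[C@@H]3Cn1cc(-c2ccccn2)nn1` differs from compound 1 by pyridin-2-yl in place of 4-methoxyphenyl on an aromatic carbon. Within the data shown here, no measured step touches this group, so no direction of change can be expected beyond the scatter. Compound 4 is estimated at 30000 nM, within 10000 nM to 100000 nM, most likely again reported as a limit. That expected step is a step that the limit leaves unreadable from compound 1 to compound 4.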

Compound 4, half-maximal inhibitory concentration: > 20000 nM
Compound 4: no number, only a limit; the forecaster's own chance of this, stated with the estimate: 80%; the middle value lies beyond the limit too.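

Compound 1 and compound 4 both give only a limit of the assay, not a number, so the change from 4-methoxyphenyl to pyridin-2-yl cannot be read as a step: the limit of > 20000 nM in this assay, at which 4 of the 4 values shown sit. The compounds shown leave open which change to the shared core, if any, would give a measurable value in this assay.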